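This account rests on a few compounds, and the source may have more. Where it says the series, first, only, none or still open, it means among the compounds named here.

Measured so far in a functional assay (aorta) with Oryctolagus cuniculus as the target; on this read-out lower numbers stand for tighter binding and higher numbers for weaker binding:
- Compound 1 `COc1cc(C(C)=O)ccc1OCCCN1CCC(CC(c2ccc(F)cc2)c2ccc(F)cc2)CC1`: 3.16 nM
- Compound 2 `COc1cc(C(C)O)ccc1OCCCN1CCC(C(c2ccc(F)cc2)c2ccc(F)cc2)CC1`: 10 nM

Of these two, compound 2 has the higher number, 10 nM, which means weaker binding, and its gap to compound 1 lies beyond the usual scatter. Compound 3 `NC(=O)c1ccc(OCCCN2CCC(C(c3ccc(F)cc3)c3ccc(F)cc3)CC2)cc1` has not yet been measured. Going from compound 2 to compound 3, 4-carbamoylphenyl takes the place of 4-(1-hydroxyethyl)-2-methoxyphenyl on an oxygen on a saturated carbon (4-carbamoylphenyl in place of 4-(1-hydroxyethyl)-2-methoxyphenyl on an oxygen on a saturated carbon). Among the compounds with values here, no measured pair shows this swap, so the expectation stays close to compound 2 at 10 nM, with a wide range. A small move toward weaker binding in this assay is expected, probably not beyond the scatter, and is estimated as a 1.6-fold higher number from compound 2 to compound 3 (0.20 log units; within the scatter). For compound 3, the estimated value is 16 nM, with an expected range from 3 nM to 80 nM.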

Compound 3, dissociation constant: 31.6 nM
The estimate for compound 3 lay 2.0-fold (0.30 log units) below the measured number, and the stated range covers the measured number.
By their numbers in this assay, from the lowest: compound 1; then compound 2; then compound 3.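

Swapping 4-(1-hydroxyethyl)-2-methoxyphenyl for 4-carbamoylphenyl on this oxygen gives a 3.2-fold higher number from compound 2 to compound 3 (0.50 log units; beyond the scatter) in this assay and shows that the group held here affects the read-out, with a modest step toward weaker binding that lies beyond the usual scatter. The swap changes more than one feature at once, as the methoxy group leaves and carbamoyl stands in for 1-hydroxyethyl, so this step alone cannot assign the change to either feature. No measurement available here accounts for the weaker binding.

Still open, from the compounds shown here alone, is whether the methoxy group or the 1-hydroxyethyl group accounts for more of the difference. Also open, going by these compounds, is how a carboxylic acid or an amine in place of the carbamoyl group would read.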